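Notes on 2-chlorobenzyl to 4-methylbenzyl in compound 1

The source may report more compounds than this note shows. Statements on the series, on what has been measured and on what is new or still open speak of the compounds shown alone.

Values so far in a functional assay on NCI-H460 cells (Homo sapiens) for cytotoxicity, read by MTT assay, with a stated time of 72 h (on this read-out lower numbers stand for stronger inhibition and higher numbers for weaker inhibition), for the series:
- compound 1 `CN(C)Cc1ccc2nc(NC(=O)N/N=C/c3cn(Cc4ccccc4Cl)c4ccccc34)sc2c1` gives 1600 nM
- compound 2 `CN(C)Cc1ccc2nc(NC(=O)N/N=C3\C(=O)Nc4ccc(Cl)cc43)sc2c1` gives 1170 nM
- compound 3 `CCN(CC)Cc1ccc2nc(NC(=O)N/N=C/c3cn(Cc4ccc(Cl)cc4Cl)c4ccccc34)sc2c1` gives 1080 nM

Compound 1 stands within the scatter of both compound 2 and compound 3, so the three numbers form a single level and set no order. Among the measured compounds shown here, no two measured compounds differ in one place, so the series holds no measured step for any structural change.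

Compound 4 `Cc1ccc(Cn2cc(/C=N/NC(=O)Nc3nc4ccc(CN(C)C)cc4s3)c3ccccc32)cc1` is still unmeasured. Against compound 1 it carries 4-methylphenyl in place of 2-chlorophenyl on a saturated chain carbon bound to an aromatic nitrogen, and 4-methylphenyl in place of 2-chlorophenyl on a saturated chain carbon bound to an aromatic nitrogen gives the count of what leaves and what enters. With no measurement on this change, the expectation rests only on the shared level, where compound 1 gives 1600 nM and compound 3 gives 1080 nM within the scatter of each other. In this assay no step beyond the scatter is expected, in either direction. The estimate amounts to a 1.2-fold lower number from compound 1 to compound 4 (0.09 log units; within the scatter) as the expected step. For compound 4 the estimated value is 1300 nM with an expected range from 550 nM to 3000 nM for the coming measurement.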

Compound 4, half-maximal inhibitory concentration: 200 nM
Compound 4: middle estimate off by 6.5-fold (0.81 log units), on the high side; measured number below the stated range.
By their numbers in this assay, from the lowest: compound 4; then compounds 3, 2 and 1 (each within the scatter of the next).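

Among the compounds shown here, the change from 2-chlorobenzyl to 4-methylbenzyl gives an 8.0-fold lower number from compound 1 to compound 4 (0.90 log units; beyond the scatter) in this assay and is the first single-place change with a measured step, one that lies beyond the scatter. The three earlier numbers formed one level and differed in more than one place, so they could not show that the group on the saturated chain carbon bound to an aromatic nitrogen can move this read-out on its own. The step comes from 2-chlorophenyl giving way to 4-methylphenyl with the heavy-atom count unchanged and the ring type, donor count and acceptor count the same, and no measurement at hand accounts for it.

The step joins two differences, the kind of substituent and its place on the ring, so the compounds shown do not separate them; 4-chlorobenzyl and 2-methylbenzyl would do so. Also open, as far as these compounds go, are the outcome with plain benzyl or 4-methoxybenzyl at this position and whether the step carries over to the diethylaminomethyl analogue.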